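This account rests on a few compounds, and the source may have more. Where it says the series, first, only, none or still open, it means among the compounds named here.

Notes on a small set of thiophene-bearing analogues tested in a functional assay on MCF7 cells (Homo sapiens) for inhibition, read by colorimetric assay and MTT assay, with a stated time of 72 h; a lower number here means a stronger inhibitor, a higher number a weaker inhibitor.

Compound 1 `COc1ccc(C(=O)NNC(=S)Nc2csc(-c3ccccc3)c2)cc1` gives 32000 nM. Compound 2 `O=C(NNC(=S)Nc1csc(-c2ccccc2)c1)c1ccc(O)cc1` gives 78000 nM. Within the data shown here, the single change between them is hydrogen in place of methyl on an oxygen on an aromatic ring, and it produced a 2.4-fold higher number from compound 1 to compound 2 (0.39 log units; beyond the scatter).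

Compound 3 `COc1ccc(-c2nnc(Nc3csc(-c4ccccc4)c3)s2)cc1` carries a different core; the difference between the cores of compound 1 and compound 3 is not broken down here. In this assay compound 3 gives 60000 nM, within the usual scatter of compound 2 and of compound 1.

Compound 4 `Oc1ccc(-c2nnc(Nc3csc(-c4ccccc4)c3)s2)cc1` has not been measured. It differs from compound 3 by hydrogen in place of methyl on an oxygen on an aromatic ring, the same change at the same place as that from compound 1 to compound 2. Carrying that step over, the expected step is a 2.2-fold higher number from compound 3 to compound 4 (0.34 log units; beyond the scatter), because a 2.4-fold higher number from compound 1 to compound 2 (0.39 log units; beyond the scatter). Compound 4 is therefore estimated at 130000 nM, within 50000 nM to 320000 nM.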

Compound 4, half-maximal inhibitory concentration: 24000 nM
The estimate for compound 4 lay 5.4-fold (0.73 log units) above the measured number; the measured number lies below the stated range.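

In this assay the change from methoxy to hydroxy gives a 2.5-fold lower number from compound 3 to compound 4 (0.40 log units; beyond the scatter) and so runs the opposite way to the step on the core of compound 1. The outcome of this change therefore depends on the core, and a step read on one of these cores cannot be carried to the other: the same change on two cores in this assay, a 2.4-fold higher number (0.39 log units; beyond the scatter) from compound 1 to compound 2 and a 2.5-fold lower number (0.40 log units; beyond the scatter) from compound 3 to compound 4, 6.1-fold (0.78 log units) apart, beyond the scatter of two such steps

This rests on a single pair for each core and does not show why the direction differs or how the change behaves on any further core. The compounds shown leave open whether a longer chain on that oxygen, such as ethoxy, follows the methoxy or the hydroxy compounds on each core. They also leave open how an amine in place of the hydroxy would compare.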